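The source may hold more compounds than are shown below. What is called first, only, known or untested is meant among the compounds shown, and "the series" means these compounds.

Measured so far:
- compound 1 `O=C(O)c1ccc(C(=O)/C(=C\c2ccc(Br)c([N+](=O)[O-])c2)SCc2ccc(Br)cc2)cc1`: 1000 nM
- compound 2 `O=C(O)c1ccc(C(=O)/C(=C\c2ccc(Br)cc2)SCc2ccc(Br)cc2)cc1`: 1000 nM
- compound 3 `O=C(/C(=C\c1ccc(O)c([N+](=O)[O-])c1)SCc1ccc(Br)cc1)c1c(F)c(F)c(F)c(F)c1F`: 10000 nM

In a functional assay on DU-145 cells (Homo sapiens) for inhibition, read by trypan blue exclusion, with a stated time of 96 h (on this read-out higher numbers stand for weaker inhibition of growth and lower numbers for stronger inhibition of growth), compound 2 gives 1000 nM, level with compound 1 within the scatter, and these two stand together at the lowest numbers of the three. Compound 3, which carries a different core as well as a different substituted ring, gives 10000 nM in this assay; as compound 3 and compound 2 differ in more than one place, their two values are noted only as they stand.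

Compound 4 `O=C(O)c1ccc(C(=O)/C(=C\c2ccc(O)c(Br)c2)SCc2ccc(Br)cc2)cc1` has not been measured. It differs from compound 2 by 3-bromo-4-hydroxyphenyl in place of 4-bromophenyl on a double-bonded chain carbon bound to a double-bonded chain carbon. Among the compounds with values here, the one step that bears on a substituent change on this ring is no change at the digits printed from compound 1 to compound 2 (within the scatter), which did not move the number beyond the scatter. Within the data shown here, no measured step introduces a hydroxy group on an otherwise unchanged core, so the expectation rests on that single step. The step from compound 2 to compound 4 is therefore expected to be small, a 1.3-fold higher number from compound 2 to compound 4 (0.11 log units; within the scatter), not beyond the scatter in either direction. Compound 4 is estimated at 1300 nM in this assay, with a range of 400 nM to 4000 nM.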

Compound 4, concentration for 50% growth inhibition: 25000 nM
Compound 4: middle estimate off by 19-fold (1.28 log units), on the low side; the measured number lies above the stated range.
By their numbers in this assay, from the lowest: compounds 1 and 2 (each within the scatter of the next); then compound 3; then compound 4.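

In this assay, the ring on a double-bonded chain carbon bound to a double-bonded chain carbon is not indifferent to substitution: 3-bromo-4-hydroxyphenyl in place of 4-bromophenyl gives a 25-fold higher number from compound 2 to compound 4 (1.40 log units; beyond the scatter), although the earlier change on this ring gave no change at the digits printed from compound 1 to compound 2 (within the scatter). The same ring in place of 4-bromo-3-nitrophenyl gives a 25-fold higher number from compound 1 to compound 4 (1.40 log units; beyond the scatter), so the large step appears against both of the rings that stood level. The data at hand offer no measured basis for explaining this step.

Compound 4 differs from compound 2 in both the hydroxy group and the placing of the bromine, so the compounds shown do not tell which of the two carries the step. Also open, as far as these compounds go, is how a methoxy group or an amine in place of the hydroxy group would read.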